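Piperazine nitrogen substituent in a triazine series

A few compounds are considered here, and "the series" means these few. Any claim that something is new, unique, unknown or untested is made for them only; others in the source may bear on it.

Measured compounds:
compound 1 `CN1CCN(c2nc(Nc3ccc(C#N)c(C(F)(F)F)c3)nc(Oc3ccnc4ccccc34)n2)CC1`: > 100000 nM
compound 2 `N#Cc1ccc(Nc2nc(Oc3ccnc4ccccc34)nc(N3CCC(Cc4ccccc4)CC3)n2)cc1C(F)(F)F`: > 100000 nM
compound 3 `COc1ccc(CN2CCN(c3nc(Nc4ccc(C#N)c(C(F)(F)F)c4)nc(Oc4ccnc5ccccc45)n3)CC2)c(OC)c1OC`: > 100000 nM

Compound 1 `CN1CCN(c2nc(Nc3ccc(C#N)c(C(F)(F)F)c3)nc(Oc3ccnc4ccccc34)n2)CC1` gives only a limit of the assay in a functional assay on DU-145 cells (Homo sapiens) for cytotoxicity, read by sulforhodamine B assay, with a stated time of 48 h (a higher number here means a weaker inhibitor of growth, a lower number a stronger inhibitor of growth), at > 100000 nM. Compound 2 `N#Cc1ccc(Nc2nc(Oc3ccnc4ccccc34)nc(N3CCC(Cc4ccccc4)CC3)n2)cc1C(F)(F)F` likewise gives only a limit in this assay, > 100000 nM. Compound 3 `COc1ccc(CN2CCN(c3nc(Nc4ccc(C#N)c(C(F)(F)F)c4)nc(Oc4ccnc5ccccc45)n3)CC2)c(OC)c1OC` also gives only a limit in this assay, > 100000 nM. Within the data shown here, the one step between compounds that differ in a single place, a step that the two limits leave unreadable from compound 1 to compound 3, cannot be read, since both ends are limits, and that is the whole of the evidence: the limit of > 100000 nM in this assay, at which 3 of the 3 values shown sit.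

Compound 4 `CC(C)N1CCN(c2nc(Nc3ccc(C#N)c(C(F)(F)F)c3)nc(Oc3ccnc4ccccc34)n2)CC1` is not yet measured. Its change from compound 1 is isopropyl in place of methyl on an amine nitrogen in a ring. Among the measured compounds shown here, the same nitrogen carried a far larger group in compound 3 without the value leaving the limit, and no measured step bears a readable size. Compound 4 is therefore expected to stay at the limit too, with an estimated value of 150000 nM (range 50000 nM to 500000 nM). The expected step that the limit leaves unreadable from compound 1 to compound 4 is estimated as none beyond the scatter.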

Compound 4, concentration for total growth inhibition: > 100000 nM
Compound 4: a limit, no number (the forecaster's own chance of this, stated with the estimate: 85%); the middle value lies beyond the limit too.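

In this assay compound 4 gives > 100000 nM, a limit and not a number; compound 1 is likewise only a limit, so the step between them cannot be read. The compounds shown leave open which change, if any, would give a readable value: the limit of > 100000 nM in this assay, at which 4 of the 4 values shown sit.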